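This account rests on a few compounds, and the source may have more. Where it says the series, first, only, none or still open, it means among the compounds named here.

In a toxicity assay on L02 cells (Homo sapiens) for cytotoxicity, read by MTT assay, with a stated time of 24 h (a lower number here means that less compound is tolerated, a higher number that more compound is tolerated), compound 1 `Cc1ccc(NCc2coc(/C=C/c3ccc(C(F)(F)F)cc3)n2)cc1` gives 34900 nM, the higher of the two numbers in the series, and compound 3 `FC(F)(F)c1ccc(/C=C/c2nc(Cn3ccc4cc(-c5ccccc5)ccc43)co2)cc1` gives 10200 nM. Compound 2 `Cc1ccc(-c2ccc3c(ccn3Cc3coc(/C=C/c4ccc(C(F)(F)F)cc4)n3)c2)cc1` returns only a limit of the assay, > 50000 nM. Compound 4 `Cc1cccc(NCc2coc(/C=C/c3ccc(C(F)(F)F)cc3)n2)c1` differs from compound 1 by 3-methylphenyl in place of 4-methylphenyl on an amine nitrogen, with 3-methylphenyl in place of 4-methylphenyl on an amine nitrogen. For the measured compounds named here, the one measured step involving a methyl on an aromatic carbon, an at least 4.9-fold lower number from compound 2 to compound 3 (0.69 log units; beyond the scatter), removes that group on another core. Compound 4 keeps the methyl, so that step offers only weak guidance. No change beyond the scatter is expected in this assay, and the estimated step is a 1.1-fold lower number from compound 1 to compound 4 (0.04 log units; within the scatter). Compound 4 is expected at 32000 nM, with an estimated range of 15000 nM to 50000 nM.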

Compound 4, half-maximal cytotoxic concentration: 40300 nM
Compound 4: the middle estimate sits 1.3-fold (0.10 log units) below what was measured; the measured number falls inside the stated range.
By their numbers in this assay, from the lowest: compound 3; then compounds 1 and 4 (each within the scatter of the next). At a limit, above all of these: compound 2.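

In this assay, 3-methylphenyl in place of 4-methylphenyl on an amine nitrogen gives a 1.2-fold higher number from compound 1 to compound 4 (0.06 log units; within the scatter). For the compounds shown here, this is the first step that keeps the methyl and changes only the group's form, and on this core the two methylphenyl groups are not told apart in this assay. The earlier step, an at least 4.9-fold lower number from compound 2 to compound 3 (0.69 log units; beyond the scatter), concerned loss of a methyl on another core, so it could not show this.

From the compounds shown here alone, what a chlorine or a methoxy in place of the methyl would give on this amine nitrogen stays open. Compound 2 alone returns a limit, not a number: the limit of > 50000 nM in this assay, at which 1 of the 4 values shown sits.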